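Hexylsulfanyl for Pentyloxy: Cytotoxicity Expected to Stay Flat

This account rests on a few compounds, and the source may have more. Where it says the series, first, only, none or still open, it means among the compounds named here.

compound 1 `CCCNc1nc(N)nc2c1ncn2/C=C1/CC1(CO)CO`: > 20000 nM, a limit of the test
compound 2 `Nc1nc(NCc2ccccc2)c2ncn(/C=C3/CC3(CO)CO)c2n1`: 19900 nM
compound 3 `CCCCCOc1nc(N)nc2c1ncn2/C=C1/CC1(CO)CO`: > 20000 nM, a limit of the test

Three compounds share one core and differ only in the group on an aromatic carbon. In an ADME assay on BCBL1 cells (Homo sapiens) for cytotoxicity, with a stated time of 7 days (on this read-out higher numbers stand for lower toxicity in this test and lower numbers for higher toxicity in this test), compound 3 stands at the limit of the test, as the limit of > 20000 nM in this assay, at which 2 of the 3 values shown sit, records. Compound 2 is the only one of the three that gives a number, and that number lies close to the limit itself. Of the steps that reach compound 3, a step that the two limits leave unreadable from compound 1 to compound 3 and a number no lower from compound 2 to compound 3 (the limit leaves the size open), neither can be read as a change beyond the scatter.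

Compound 4 `CCCCCCSc1nc(N)nc2c1ncn2/C=C1/CC1(CO)CO` differs from compound 3 in one place: hexylsulfanyl in place of pentyloxy on an aromatic carbon. Every measured change of this group on the same aromatic carbon has left the read-out at or near the limit, so the step to compound 4 is expected to be none beyond the scatter, a number no higher from compound 3 to compound 4 (the limit leaves the size open). Compound 4 is therefore estimated to give 20000 nM, within 10000 nM to 40000 nM.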

Compound 4, half-maximal cytotoxic concentration: > 20000 nM
Compound 4 was reported as a limit; the forecaster's own chance of this, stated with the estimate: 75%; the middle value lies on the limit itself.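

In this assay compound 4 is also reported only as a limit, so hexylsulfanyl now joins pentyloxy and propylamino among the groups on this aromatic carbon that leave the read-out at the limit of the test: the limit of > 20000 nM in this assay, at which 3 of the 4 values shown sit. Within the data shown here, the only new step with a direction is a number no lower from compound 2 to compound 4 (the limit leaves the size open). The steps that link compound 4 to compound 1 and compound 3 cannot be read, with a limit at each end, so the result adds a sulfur-linked chain to this set but gives no size for the change.

As far as these compounds go, how far compound 1, compound 3 and compound 4 lie past the limit stays open, and they cannot be ranked. Also open, from the compounds shown here alone, is whether a carboxylic acid or a morpholine on this aromatic carbon would give a number in this test.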